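From anilino to a methylpyrazolyl amino group

The compounds below may be only part of what the source reports. "The series", "measured", "known", "first", "only" and "open" are said of these compounds alone.

Compound 1 `O=C(Nc1ccc(Nc2nccc(NC3CC3)n2)cc1)Nc1ccc(Cl)c(C(F)(F)F)c1`: 18500 nM
Compound 2 `O=C(Nc1ccc(Nc2nccc(Nc3ccccc3)n2)cc1)Nc1ccc(Cl)c(C(F)(F)F)c1`: > 50000 nM (a limit)
Compound 3 `O=C(Nc1ccc(Nc2nccc(Nc3cccc(Cl)c3)n2)cc1)Nc1ccc(Cl)c(C(F)(F)F)c1`: 8050 nM

In a functional assay on A549 cells (Homo sapiens) for antiproliferative activity, read by MTT assay, with a stated time of 72 h (on this read-out lower numbers stand for stronger inhibition and higher numbers for weaker inhibition), compound 2 gives only a limit, > 50000 nM, and not a number. Compound 4 `Cn1cc(Nc2ccnc(Nc3ccc(NC(=O)Nc4ccc(Cl)c(C(F)(F)F)c4)cc3)n2)cn1` differs from it by carrying 1-methyl-1H-pyrazol-4-yl in place of phenyl on a nitrogen on an aromatic ring. Three measured steps at this nitrogen bear on the change: an at least 2.7-fold higher number from compound 1 to compound 2 (0.43 log units; beyond the scatter), a 2.3-fold lower number from compound 1 to compound 3 (0.36 log units; beyond the scatter) and an at least 6.2-fold lower number from compound 2 to compound 3 (0.79 log units; beyond the scatter). None of them tests a five-membered ring. Given an at least 6.2-fold lower number from compound 2 to compound 3 (0.79 log units; beyond the scatter), a modest move toward a lower number is expected, though a second limit remains possible. The expected change is an at least 2.5-fold lower number from compound 2 to compound 4 (0.39 log units; beyond the scatter). Compound 4 is estimated at 20000 nM, with an expected range from 7000 nM to 50000 nM.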

Compound 4, half-maximal inhibitory concentration: 8610 nM
For compound 4 the middle estimate is 2.3-fold (0.37 log units) above the measured one; the measured number falls inside the stated range.
By their numbers in this assay, from the lowest: compounds 3 and 4 (each within the scatter of the next); then compound 1. At a limit, above all of these: compound 2.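

Compound 2 gives a limit and not a number: the limit of > 50000 nM in this assay, at which 1 of the 4 values shown sits. In this assay, a five-membered ring on this nitrogen still gives a measurable value, with an at least 5.8-fold lower number from compound 2 to compound 4 (0.76 log units; beyond the scatter) and a 2.1-fold lower number from compound 1 to compound 4 (0.33 log units; beyond the scatter). Within the data shown here, the 1-methyl-1H-pyrazol-4-yl group also matches the 3-chlorophenyl group, with a 1.1-fold higher number from compound 3 to compound 4 (0.03 log units; within the scatter), so a chloro on a six-membered ring is not the only change at this nitrogen that gives such a value. The compounds shown leave open what the methyl on the pyrazole contributes. They also leave open how an unmethylated pyrazol-4-yl or a pyridinyl group would compare at this nitrogen.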